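The source may hold more compounds than are shown below. What is called first, only, known or untested is meant among the compounds shown, and "the series" means these compounds.

Measured so far in a functional assay on MOLT-4 cells (Homo sapiens) for cytotoxicity, read by CCK-8 assay, with a stated time of 24 h; a lower number here means a stronger inhibitor, a higher number a weaker inhibitor:
- compound 1 `C=CC(=O)N1C(=O)CC(c2ccc(OC)cc2)Sc2ccccc21` gives 83200 nM
- compound 2 `C=CC(=O)N1C(=O)CC(C)Sc2ccccc21` gives 730000 nM
- compound 3 `C=CC(=O)N1C(=O)CC(c2cccc(Cl)c2)Sc2ccccc21` gives 77500 nM

On these numbers, compound 1 sits level with compound 3 and well under compound 2. Compound 4 `C=CC(=O)N1C(=O)CC(c2ccc(-c3ccccc3)cc2)Sc2ccccc21` has not yet been measured. Its difference from compound 1 is phenyl in place of methoxy on an aromatic carbon and the new group sits para to a large group.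

The closest measured change also swaps one substituted phenyl for another: 3-chlorophenyl in place of 4-methoxyphenyl gave a 1.1-fold lower number from compound 1 to compound 3 (0.03 log units; within the scatter) and so no real shift. Larger steps appeared only where methyl was involved on the saturated ring carbon, namely an 8.8-fold higher number from compound 1 to compound 2 (0.94 log units; beyond the scatter) and a 9.4-fold lower number from compound 2 to compound 3 (0.97 log units; beyond the scatter) in the opposite direction. Compound 4 keeps a substituted phenyl there, so those larger steps are not the expected guide. Within the data shown here, only two such phenyl compounds have been measured, however, and neither carries a second ring on its phenyl, so the range must stay wide.

The expected result is a 1.2-fold lower number from compound 1 to compound 4 (0.08 log units; within the scatter) and so no step beyond the usual scatter. For compound 4 the estimated value is 70000 nM with an expected range from 30000 nM to 170000 nM in this assay.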

Compound 4, half-maximal inhibitory concentration: 97500 nM
The estimate for compound 4 lay 1.4-fold (0.14 log units) below the measured number; measured number inside the range.
By their numbers in this assay, from the lowest: compounds 3, 1 and 4 (each within the scatter of the next); then compound 2.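

In this assay, phenyl in place of methoxy on the aromatic carbon gave a 1.2-fold higher number from compound 1 to compound 4 (0.07 log units; within the scatter) and so no step beyond the scatter. The earlier compounds shown here had only compared one substituted phenyl with another, and none carried a second ring on that phenyl. This result adds that a six-membered aromatic ring of carbon only, with no hydrogen-bond acceptor, can stand para to a large group in place of methoxy without a readable change in this cell test, and no evidence is available to explain this result.

Still open, going by these compounds, is whether an amine or a carboxylic acid on the same aromatic carbon would shift the number beyond the scatter. A longer chain in place of the second ring at this position is equally untested in the compounds shown here.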